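The compounds below may be only part of what the source reports. "The series", "measured", "known", "first", "only" and "open" are said of these compounds alone.

Compound 1 `CCCCOC(=O)CCC(=O)N1CCN(CCCOc2cc3c(Nc4ccc(F)c(Cl)c4)ncnc3cc2OC)CC1`, compound 2 `CCCCCOC(=O)CCC(=O)N1CCN(CCCOc2cc3c(Nc4ccc(F)c(Cl)c4)ncnc3cc2OC)CC1` and compound 3 `CCCCCCCCCCCOC(=O)CCC(=O)N1CCN(CCCOc2cc3c(Nc4ccc(F)c(Cl)c4)ncnc3cc2OC)CC1` share one core and differ only in the length of the ester chain. In a functional assay on A549 cells (Homo sapiens) for cytotoxicity, read by MTT assay, with a stated time of 24 h, tested at 80 uM (on this read-out lower numbers stand for a stronger effect and higher numbers for a weaker effect at the one concentration tested), compound 1 gives 36.9%, compound 2 gives 18.2% and compound 3 gives 2.8%. The steps run a number 18.7 percentage points lower from compound 1 to compound 2 (beyond the scatter), a number 15.4 percentage points lower from compound 2 to compound 3 (beyond the scatter) and a number 34.1 percentage points lower from compound 1 to compound 3 (beyond the scatter), so compound 3 gives the lowest number of the three. Compound 4 `CCCCCCCCCCCCOC(=O)CCC(=O)N1CCN(CCCOc2cc3c(Nc4ccc(F)c(Cl)c4)ncnc3cc2OC)CC1` is not yet measured; it arises from compound 3 by methyl in place of hydrogen on a saturated chain carbon, ten or more bonds along the chain from an oxygen next to a carbonyl group. The same kind of change, (methyl in place of hydrogen on a saturated chain carbon, four bonds along the chain from an oxygen next to a carbonyl group), earlier made the step of a number 18.7 percentage points lower from compound 1 to compound 2 (beyond the scatter). The two cores differ by heptyl in place of hydrogen on a saturated chain carbon, four bonds along the chain from an oxygen next to a carbonyl group, and the place of the change along the chain is not the same in the two cases. Compound 3 already sits close to the bottom of the scale, so compound 4 is expected to move only a number 0.8 percentage points lower from compound 3 to compound 4 (within the scatter). Compound 4 is estimated at 2%, between 0% and 12%.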

Compound 4, a percentage reported as activity, at one concentration (the size of the read-out at that concentration, not a potency): 2.3%
The estimate for compound 4 lay 0.3 percentage points below the measured number; low and high end bracket the measured number.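

In this assay the methyl change does not carry over in size from one core to the other, since it now gives a number 0.5 percentage points lower from compound 3 to compound 4 (within the scatter): the same change on two cores in this assay, a number 18.7 percentage points lower (beyond the scatter) from compound 1 to compound 2 and a number 0.5 percentage points lower (within the scatter) from compound 3 to compound 4, 18.2 percentage points apart, beyond the scatter of two such steps
The heptyl change also differs by core, and the whole chain extensions give a number 15.9 percentage points lower from compound 2 to compound 4 (beyond the scatter) and a number 34.6 percentage points lower from compound 1 to compound 4 (beyond the scatter): the same change on two cores in this assay, a number 34.1 percentage points lower (beyond the scatter) from compound 1 to compound 3 and a number 15.9 percentage points lower (beyond the scatter) from compound 2 to compound 4, 18.2 percentage points apart, beyond the scatter of two such steps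
This shows that the size of a step depends on the core carrying it, but with compound 3 and compound 4 close to the bottom of the scale, it does not show whether the chain has stopped mattering or the read-out has simply run out of room.

The compounds shown leave open how a branched chain, or a chain ending in an amine or a carboxylic acid, would read. Also open, as far as these compounds go, are chains longer than that of compound 2 but shorter than that of compound 3, which could show where the read-out levels off.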